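The compounds below may be only part of what the source reports. "The series", "measured", "known", "first", "only" and "open" are said of these compounds alone.

Working notes on the series. In a toxicity assay on CHO cells (Cricetulus griseus) for cytotoxicity, read by MTT assay, with a stated time of 72 h (on this read-out higher numbers stand for weaker inhibition and lower numbers for stronger inhibition), compound 1 `COc1ccc(/C=C2\S/C(=N\c3ccccc3)N(Cc3ccco3)C2=O)cc1OC` gives > 250000 nM, which is a limit of the assay and not a number. Compound 2 `O=C1/C(=C/c2cccc(Cl)c2)S/C(=N\c2ccccc2)N1Cc1ccco1` has no number of its own, its result being "not determined" (no result reported). The only reference point nearby is the limit of > 250000 nM in this assay, at which 1 of the 2 values shown sits. Compound 3 `Cc1ccc(/C=C2\S/C(=N\c3ccccc3)N(Cc3ccco3)C2=O)cc1` is still unmeasured. The structural change 4-methylphenyl in place of 3-chlorophenyl on a double-bonded chain carbon bound to a double-bonded ring carbon places 4-methylphenyl in place of 3-chlorophenyl on a double-bonded chain carbon bound to a double-bonded ring carbon. Going by the values given here, no measured step exists, so a shift no larger than the scatter is expected in this assay, with no direction assigned. For compound 3 the estimated value is 200000 nM, with an expected range of 80000 nM to 400000 nM.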

Compound 3, half-maximal inhibitory concentration: 185000 nM
For compound 3 the middle estimate is 1.1-fold (0.03 log units) above the measured one; measured number inside the range.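

In this assay the place on a double-bonded chain carbon bound to a double-bonded ring carbon now has its first actual number, with 4-methylphenyl in compound 3 at 185000 nM. Putting 4-methylphenyl in place of 3,4-dimethoxyphenyl gives an at least 1.3-fold lower number from compound 1 to compound 3 (0.13 log units; that floor lies within the scatter), so no real shift can be claimed. That step is only a floor because compound 1 stands at a limit of the assay: the limit of > 250000 nM in this assay, at which 1 of the 3 values shown sits.

The step between compound 2 and compound 3 cannot be read. From the compounds shown here alone, whether an amine or a carboxylic acid at this place would give a much lower number remains open.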